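A few compounds are considered here, and "the series" means these few. Any claim that something is new, unique, unknown or untested is made for them only; others in the source may bear on it.

Measured compounds:
- compound 1, `O=Cc1ccc(-c2cn3ccnc3c(-c3ccc4ncn(C5CCCCC5)c4c3)n2)cc1`: 56.5%
- compound 2, `Fc1ccc(-c2cn3ccnc3c(-c3ccc4ncn(C5CCCCC5)c4c3)n2)cc1`: 7.36%

Both values come from a functional assay on SK-MEL-5 cells (Homo sapiens) for inhibition, read by sulforhodamine B assay, with a stated time of 48 h, tested at 10 uM; on this read-out lower numbers stand for less inhibition and higher numbers for more inhibition at the one concentration tested (going by the name of the read-out). Within the data shown here, compound 2 stands lowest of the two numbers; its only neighbour is compound 1, and the step of a number 49.1 percentage points lower from compound 1 to compound 2 (beyond the scatter) is the single measured step.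

Compound 3, `Clc1ccc(-c2cn3ccnc3c(-c3ccc4ncn(C5CCCCC5)c4c3)n2)cc1`, differs from compound 2 by chloro in place of fluoro on an aromatic carbon. Among the measured compounds shown here, no measured step concerns a chloro for fluoro exchange: the one step known, from formyl to fluoro on that same aromatic carbon, is of another kind, so it does not transfer to this change. With nothing to point either way, the step of a number 6.6 percentage points higher from compound 2 to compound 3 (within the scatter) is expected to stay within the scatter, although a swing of some size in either direction cannot be excluded.

Compound 3 is therefore estimated at 14% in this assay, with a range from 0% to 38%.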

Compound 3, a percentage reported as inhibition, at one concentration (the size of the read-out at that concentration, not a potency): 12.4%
Compound 3: the middle estimate sits 1.6 percentage points above what was measured; low and high end bracket the measured number.
By their numbers in this assay, from the lowest: compounds 2 and 3 (each within the scatter of the next); then compound 1.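

In this assay, chloro in place of fluoro on this aromatic carbon gives a number 5 percentage points higher from compound 2 to compound 3 (within the scatter) and so the two halogens cannot be told apart here. Formyl now stands apart from both, with a number 44.1 percentage points lower from compound 1 to compound 3 (beyond the scatter) on record alongside a number 49.1 percentage points lower from compound 1 to compound 2 (beyond the scatter) and so the gap to compound 1 is no longer tied to fluoro alone. No measurement at hand accounts for the difference between formyl and the two halogens.

Still open, from the compounds shown here alone, is whether the higher number belongs to formyl alone or is shared by other groups on this aromatic carbon, such as a carboxylic acid, a hydroxymethyl group or an amine. Also open, going by these compounds, is whether the gap seen at the one concentration tested carries over to other concentrations or other cell lines.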